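The source may report more compounds than this note shows. Statements on the series, on what has been measured and on what is new or still open speak of the compounds shown alone.

In an ADME assay on MT4 cells (Homo sapiens) for cytotoxicity, read by MTT assay, with a stated time of 96 h (a higher number here means that more compound is tolerated, a lower number that less compound is tolerated), compound 1 `Brc1ccc(NCc2cn(-c3ccccc3)nc2-c2ccccc2)cc1` gives > 100000 nM, a limit of the assay and not a number. Compound 2 `Cc1ccc(NCc2cn(-c3ccccc3)nc2-c2ccc(Cl)cc2)cc1` gives > 100000 nM, also a limit. Compound 3 `FC(F)(F)c1ccc(NCc2cn(-c3ccccc3)nc2-c2ccc(C(F)(F)F)cc2)cc1` gives > 100000 nM, again a limit. Going by the values given here, compound 2 therefore has no exact value, and the series so far stands at the limit of > 100000 nM in this assay, at which 3 of the 3 values shown sit.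

Compound 4 `Cc1ccc(NCc2cn(-c3ccccc3)nc2-c2ccc(C)cc2)cc1` is the next compound to be read. It differs from compound 2 by methyl in place of chloro on an aromatic carbon, para to a large group: methyl in place of chloro on an aromatic carbon. Among the compounds with values here, no pair of measured compounds differs in one place, so no measured step is available as a guide. In this assay, no change beyond the scatter is expected, in either direction. This expectation rests on compound 2, whose result of > 100000 nM is a limit. The estimated step of a number no higher from compound 2 to compound 4 (the limit leaves the size open) is expected to stay within the scatter, and another limit is the likely report. For compound 4 the estimated value is 100000 nM, with an expected range of 50000 nM to 200000 nM.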

Compound 4, half-maximal cytotoxic concentration: > 100000 nM
Compound 4 was reported as a limit; the forecaster's own chance of this, stated with the estimate: 85%; the middle value sits exactly at the limit.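

In this assay, compound 2 and compound 4 are both reported as limits and not numbers, so no step between them can be read: the limit of > 100000 nM in this assay, at which 4 of the 4 values shown sit.

The compounds shown leave open where any exact value lies in this assay, and whether methyl in place of chloro on an aromatic carbon changes it at all.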